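The source may hold more compounds than are shown below. What is called first, only, known or untested is meant among the compounds shown, and "the series" means these compounds.

Measured so far:
Compound 1, `N[C@@H](COP(=O)(O)OCCCOC(=O)CCc1ccccc1OCc1cccc(Oc2ccccc2)c1)C(=O)O`, gives 0.48 in an assay on cells for activation of probable G-protein coupled receptor 34 (Mus musculus), with a stated time of 1 h; a lower number here means a smaller maximal response, a higher number a larger maximal response.
Compound 2, `N[C@@H](COP(=O)(O)OCCCOC(=O)CCc1ccccc1OCc1cccc(Oc2ccc(Cl)cc2)c1)C(=O)O`, gives 0.76 in this assay.

Compound 2 holds the higher of the two numbers. Among the measured compounds shown here, the one measured step, a number 0.28 higher from compound 1 to compound 2 (beyond the scatter), lies beyond the scatter and records what a chloro group brought when it took the place of hydrogen on that aromatic carbon. Compound 3, `CCc1ccc(Oc2cccc(COc3ccccc3CCC(=O)OCCCOP(=O)(O)OC[C@H](N)C(=O)O)c2)cc1`, is the next step from compound 2. The change is ethyl in place of chloro on an aromatic carbon. For the measured compounds named here, no measured pair shows ethyl replacing chloro, so the only step that bears on it is a number 0.28 higher from compound 1 to compound 2 (beyond the scatter), which tells that a group at this place, para to a large group, raised the response modestly; it does not tell whether ethyl and chloro act alike there. Since ethyl enters the very place that chloro leaves, the response is expected to stay close to that of compound 2 rather than fall back toward compound 1, and the expected step a number 0.040 lower from compound 2 to compound 3 (within the scatter) is within the scatter. Compound 3 is therefore estimated at 0.72, with a range from 0.55 to 0.9.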

Compound 3, intrinsic activity: the largest response reached, as a fraction of the reference agonist's: 0.42
Beside the measured number, compound 3's estimate is 0.30 above it; the whole stated range lies above it.
By their numbers in this assay, from the lowest: compounds 3 and 1 (each within the scatter of the next); then compound 2.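

At this place, on an aromatic carbon para to a large group, the rise in maximal response that came with chloro does not carry over to ethyl (a number 0.34 lower from compound 2 to compound 3 (beyond the scatter)). Set against hydrogen at the same carbon, ethyl brings no change that can be told from the scatter (a number 0.060 lower from compound 1 to compound 3 (within the scatter)), so in this assay compound 3 and compound 1 stand together, with compound 2 above both. Simply filling this place with a group is therefore not enough to raise the response, and of the two groups shown here, only chloro does so.

Nothing available explains why chloro and ethyl part ways at this carbon. From the compounds shown here alone, it also remains open whether bromo, methyl or methoxy at the same place would behave like chloro or like ethyl, and whether a longer chain such as propyl would match ethyl in giving a response that cannot be told apart from that with hydrogen.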